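The compounds below may be only part of what the source reports. "The series", "measured", "known", "first", "only" and "open" are said of these compounds alone.

Compound 1 `Cc1ccc2[nH]c(=O)c(CN(Cc3ccc(C(N)=O)cc3)Cc3ccc(C(C)(C)C)cc3)cc2c1` carries on its amine nitrogen a 4-carbamoylbenzyl group. In a toxicity assay on MDCK cells (Canis lupus familiaris) for cytotoxicity, read by crystal violet staining, with a stated time of 48 h (on this read-out higher numbers stand for lower toxicity in this test and lower numbers for higher toxicity in this test), compound 1 gives only a limit of the assay, > 5000 nM, not a number. Compound 2 `CCc1ccc2[nH]c(=O)c(CN(Cc3ccc(C(C)(C)C)cc3)C(C)c3ccc(OC)cc3)cc2c1` is a close relative with a different core substituent and a 1-(4-methoxyphenyl)ethyl group in place of the carbamoylbenzyl. In this assay compound 2 likewise reaches only a limit, > 5000 nM. Both values shown therefore sit at the same boundary (the limit of > 5000 nM in this assay, at which 2 of the 2 values shown sit), so nothing yet separates them in the numbers.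

Compound 3 `Cc1ccc2[nH]c(=O)c(CN(Cc3ccc(C(C)(C)C)cc3)C(C)c3ccc(OC(F)F)cc3)cc2c1` arises from compound 1 through the change (1-(4-(difluoromethoxy)phenyl)ethyl in place of 4-carbamoylbenzyl on an amine nitrogen). No measured pair in this set differs in a single place, so no step size can be read off; on the evidence shown, the expected step in this assay from compound 1 to compound 3 is none beyond the scatter, meaning a further limit rather than a value, a step that the limit leaves unreadable from compound 1 to compound 3. Compound 3 is therefore estimated to give 8000 nM, within 4000 nM to 20000 nM.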

Compound 3, half-maximal cytotoxic concentration: > 5000 nM
Compound 3: a limit, no number; the forecaster's own chance of this, stated with the estimate: 80%; the middle value lies beyond the limit too.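

No step can be read from compound 1 to compound 3, because both values stop at the same boundary: the limit of > 5000 nM in this assay, at which 3 of the 3 values shown sit.

The compounds shown leave open how far past that limit each lies, and whether any group on the amine nitrogen would give an actual number in this assay.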